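Fluoro for Nitro: Expectations for Compound 4

This account rests on a few compounds, and the source may have more. Where it says the series, first, only, none or still open, it means among the compounds named here.

The study measured three compounds in an in vitro assay on BTI-TN-5B1-4 cells for inhibition of Amine oxidase [flavin-containing] A (Homo sapiens), read by Amplex Red, with a stated time of 15 min, tested at 100 uM; a lower number here means less inhibition, a higher number more inhibition at the concentration tested (going by the name of the read-out). Compound 1 `C/C(=N/Nc1nc(-c2ccc(C#N)cc2)cs1)c1ccco1` gives 40% in this assay. Compound 2 `O=[N+]([O-])c1ccc(-c2csc(N/N=C\c3ccncc3)n2)cc1` was reported in this assay as "not active" (no number reported). Compound 3 `C/C(=C/CC1=CC(c2ccc([N+](=O)[O-])cc2)=CC1)c1ccc2ccccc2c1` was likewise reported in this assay as "not active" (no number reported), so no single number stands for it, and it is one of two entries in this assay without a number. Going by the values given here, no step between compound 3 and any measured compound can therefore be stated.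

Compound 4 `C/C(=C/CC1=CC(c2ccc(F)cc2)=CC1)c1ccc2ccccc2c1` has not yet been measured. It differs from compound 3 in one place: fluoro in place of nitro on an aromatic carbon. Among the compounds with values here, no pair of measured compounds shows what such a change does in this assay, so the expectation rests on compound 3 alone. Because compound 3 is reported as "not active" (no number reported), compound 4 is expected to show only weak inhibition in this assay, with no step beyond the scatter. The estimate for compound 4 in this assay is 10%, with a range from 0% to 35%.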

Compound 4, a percentage reported as inhibition, at one concentration (the size of the read-out at that concentration, not a potency): 40%
Compound 4: middle estimate off by 30 percentage points, on the low side; measured number above the stated range.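

In this assay, going by these compounds alone, compound 4 gives 40%, but compound 3 has no single number, so no step between compound 3 and compound 4 can be read. The compounds shown leave open how 4-nitrophenyl to 4-fluorophenyl changes inhibition. Nothing further shown here bears on this result.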